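The compounds below may be only part of what the source reports. "The series", "measured", "known", "first", "only" and "open" are said of these compounds alone.

Measured so far:
compound 1 `ClCc1cccc(Cn2cnc3c(Cl)nc(Cl)nc32)c1` with > 100000 nM
compound 2 `ClCc1ccccc1Cn1cnc2ncnc(Cl)c21` with 4260 nM

In a functional assay on MOLT-4 cells (Homo sapiens) for cytotoxicity, read by sulforhodamine B assay, with a stated time of 48 h (a lower number here means a stronger inhibitor of growth, a higher number a weaker inhibitor of growth), compound 1 gives only a limit, > 100000 nM. In this assay compound 2 gives 4260 nM, the only number shown, with one further value sitting at the limit of > 100000 nM in this assay, at which 1 of the 2 values shown sits. Compound 3 `ClCc1ccccc1Cn1cnc2nc(Cl)nc(Cl)c21` is not yet measured. It differs from compound 2 by chloro in place of hydrogen on an aromatic carbon. Among the compounds with values here, no single-change step between measured compounds exists here, so the size of this step is guessed. Compound 3 is expected to be a weaker inhibitor of growth, by a 2.3-fold higher number from compound 2 to compound 3 (0.37 log units; beyond the scatter). For compound 3 the estimate in this assay is 10000 nM, with a range from 2000 nM to 60000 nM.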

Compound 3, concentration for total growth inhibition: 3230 nM
Estimate against measurement, compound 3: 3.1-fold (0.49 log units) above; low and high end bracket the measured number.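

In this assay, chloro in place of hydrogen on the aromatic carbon between two ring nitrogen atoms gives a 1.3-fold lower number from compound 2 to compound 3 (0.12 log units; within the scatter) and so leaves the two compounds indistinguishable. Within the data shown here, this is the first change at this position that can be read, and it shows that growth inhibition in this cell line persists with chloro on this carbon. Nothing available here offers a reason for this result. From the compounds shown here alone, whether an amine, a methoxy group or a longer chain on this same carbon would give a similar number remains open.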